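The compounds below may be only part of what the source reports. "The series", "measured", "known", "first", "only" and "open" are said of these compounds alone.

In a functional assay on M21 cells (Homo sapiens) for antiproliferative activity, read by sulforhodamine B assay, with a stated time of 48 h (a lower number here means a stronger inhibitor, a higher number a weaker inhibitor), compound 1 `O=C1NCCN1c1ccc(S(=O)(=O)Nc2ccccc2)cc1` gives 200 nM and compound 3 `Cc1ccc(NS(=O)(=O)c2ccc(N3CCNC3=O)cc2)c(C)c1` gives 150 nM. Compound 2 `CC(C)(C)c1ccc(NS(=O)(=O)c2ccc(N3CCNC3=O)cc2)cc1` gives > 1000 nM, which is a limit of the assay and not a number; this is the limit of > 1000 nM in this assay, at which 1 of the 3 values shown sits. Compound 4 `CC(C)Cc1ccc(NS(=O)(=O)c2ccc(N3CCNC3=O)cc2)cc1` differs from it by isobutyl in place of tert-butyl on an aromatic carbon, para to a large group. Going by the values given here, two measured steps bear on this. Adding tert-butyl gave an at least 5.0-fold higher number from compound 1 to compound 2 (0.69 log units; beyond the scatter), which is beyond the scatter. The 2,4-dimethylphenyl change gave a 1.3-fold lower number from compound 1 to compound 3 (0.12 log units; within the scatter), which is within it. Among the compounds with values here, no measured step covers isobutyl itself, so a moderate move toward stronger inhibition in this assay is expected, with much uncertainty. The expected change is an at least 1.4-fold lower number from compound 2 to compound 4 (0.15 log units; that floor lies within the scatter). For compound 4 the estimate is 700 nM, with an expected range of 250 nM to 2000 nM.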

Compound 4, half-maximal inhibitory concentration: > 1000 nM
Compound 4 gave a limit, no number; the forecaster's own chance of this, stated with the estimate: 35%; middle value at least 1.4-fold (0.15 log units) from the limit.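

In this assay, isobutyl in place of hydrogen at this position gives an at least 5.0-fold higher number from compound 1 to compound 4 (0.69 log units; beyond the scatter), so the loss seen with tert-butyl is not confined to that one branched chain. Compound 4 gives only a limit of the assay, not a number. The step between the two chains cannot be read, and both compounds sit at the same limit: the limit of > 1000 nM in this assay, at which 2 of the 4 values shown sit.

On these data alone, how far either compound lies past that limit stays open, so tert-butyl and isobutyl cannot be ranked. As far as these compounds go, whether a shorter chain such as ethyl, or an amine, would stay close to compound 1 also stays open.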